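Swapping methylsulfanyl for 2-methylphenyl

The source may hold more compounds than are shown below. What is called first, only, known or untested is meant among the compounds shown, and "the series" means these compounds.

compound 1 `CCC1=C(O)c2c(oc(-c3ccc(C(F)(F)F)cc3)cc2=O)C(CC)(CC)C1=O` gives 10.4 uM
compound 2 `CCCOc1ccc(-c2cc(=O)c3c(o2)C(CC)(CC)C(=O)C(CC)=C3O)cc1` gives 29.2 uM
compound 3 `CCC1=C(O)c2c(oc(-c3ccc(SC)cc3)cc2=O)C(CC)(CC)C1=O` gives 1.38 uM

All three values come from a functional assay on KBVIN cells (Homo sapiens) for antiproliferative activity, read by sulforhodamine B assay, with a stated time of 3 days (on this read-out lower numbers stand for an effect already at smaller amounts and higher numbers for an effect only at larger amounts of compound), and compound 3 has the lowest number of the three, with its steps to both others beyond the scatter. The next structure is compound 4 `CCC1=C(O)c2c(oc(-c3ccccc3C)cc2=O)C(CC)(CC)C1=O` which carries 2-methylphenyl in place of 4-(methylsulfanyl)phenyl on an aromatic carbon next to the ring oxygen 2-methylphenyl in place of 4-(methylsulfanyl)phenyl on an aromatic carbon while the shared core stays the same.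

Going by the values given here, two measured steps bear on this change. Putting methylsulfanyl in place of trifluoromethyl gave a 7.5-fold lower number from compound 1 to compound 3 (0.88 log units; beyond the scatter) and putting it in place of propoxy gave a 21-fold lower number from compound 2 to compound 3 (1.33 log units; beyond the scatter) so both other groups sat at higher numbers than methylsulfanyl. These steps were modest and large in size. Neither involves a 2-methylphenyl group, so they guide the expectation only loosely.

Losing the 4-(methylsulfanyl)phenyl group is therefore expected to move the number upward, and the estimate is a 5.8-fold higher number from compound 3 to compound 4 (0.76 log units; beyond the scatter) in this assay as a modest step. The expected value for compound 4 is 8 uM with an estimated range of 2.5 uM to 25 uM for repeat measurements.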

Compound 4, concentration for half-maximal effect: 2.41 uM
The estimate for compound 4 lay 3.3-fold (0.52 log units) above the measured number; the whole stated range lies above it.
By their numbers in this assay, from the lowest: compounds 3 and 4 (each within the scatter of the next); then compound 1; then compound 2.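

In this assay the swap of 4-(methylsulfanyl)phenyl for 2-methylphenyl gives a 1.7-fold higher number from compound 3 to compound 4 (0.24 log units; within the scatter) and so leaves the two compounds indistinguishable on this read-out. Going by these compounds alone, until now methylsulfanyl was the only group on this ring with a low number, since the steps from trifluoromethyl and from propoxy both ended at compound 3; that could have suggested that the sulfur-bearing group was needed. Compound 4 shows that this position can hold a ring without sulfur, with its methyl group placed differently, and still give a number that cannot be separated from that of compound 3, although nothing shown explains why these two groups read alike.

The compounds shown leave open whether the ring position of the methyl group matters, since a direct comparison would need 4-methylphenyl alongside 2-methylphenyl on the same core. Going by these compounds, how this position would respond to a ring carrying an amine or a carboxylic acid also stays open, and so does whether a longer chain such as 2-ethylphenyl would keep the number close to those of compound 3 and compound 4.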